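One Methyl Group, Two Compound Pairs, One Cell Assay

A few compounds are considered here, and "the series" means these few. Any claim that something is new, unique, unknown or untested is made for them only; others in the source may bear on it.

Measured compounds:
compound 1, `O=C(Nc1cccc(-n2cc(-c3ccncc3)c(-c3cc(O)cc(Cl)c3)n2)c1)Nc1ccc(Cl)c(Cl)c1`, 16.2%
compound 2, `COc1cc(Cl)cc(-c2nn(-c3cccc(NC(=O)Nc4ccc(Cl)c(Cl)c4)c3)cc2-c2ccncc2)c1`, 25.3%
compound 3, `O=C(Nc1cccc(-n2cc(-c3ccncc3)c(-c3cc(O)cc(Cl)c3)n2)c1)c1cc(C(F)(F)F)cc(C(F)(F)F)c1`, 69.4%

In a functional assay on SF-268 cells (Homo sapiens) for inhibition, read by sulforhodamine B assay, with a stated time of 48 h, tested at 10 uM (on this read-out higher numbers stand for a weaker effect at the one concentration tested and lower numbers for a stronger effect), compound 1 gives 16.2% and compound 2 gives 25.3%. The change between them is methyl in place of hydrogen on an oxygen on an aromatic ring, and the step it made is a number 9.1 percentage points higher from compound 1 to compound 2 (within the scatter). Compound 3 gives 69.4% in this assay; how its core differs from that of compound 1 is not broken down here. Compound 4, `COc1cc(Cl)cc(-c2nn(-c3cccc(NC(=O)c4cc(C(F)(F)F)cc(C(F)(F)F)c4)c3)cc2-c2ccncc2)c1`, has not yet been measured. It differs from compound 3 by methyl in place of hydrogen on an oxygen on an aromatic ring, the same kind of change as between compound 1 and compound 2, at a place described in the same words. On the strength of that single earlier step a number 9.1 percentage points higher from compound 1 to compound 2 (within the scatter), compound 4 is expected to sit close to compound 3, with an estimated step of a number 5.6 percentage points higher from compound 3 to compound 4 (within the scatter). The estimated value for compound 4 in this assay is 75%, likely between 55% and 92%.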

Compound 4, a percentage reported as activity, at one concentration (the size of the read-out at that concentration, not a potency): 89.2%
Beside the measured number, compound 4's estimate is 14.2 percentage points below it; low and high end bracket the measured number.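

In this assay, replacing hydroxy with methoxy on the 3-chloro-5-hydroxyphenyl group gave a number 19.8 percentage points higher from compound 3 to compound 4 (beyond the scatter). Set beside the earlier pair, the two steps cannot be told apart: the same change on two cores in this assay, a number 9.1 percentage points higher (within the scatter) from compound 1 to compound 2 and a number 19.8 percentage points higher (beyond the scatter) from compound 3 to compound 4, 10.7 percentage points apart, within the scatter of two such steps. So, as far as this one read-out goes, the change carries from one core to the other, but two pairs do not fix its size on either core or show that it would carry to any further core.

The compounds shown leave open how a longer chain on that oxygen, such as ethoxy, or an amine in place of the hydroxy, would read. They also leave open whether methyl on that oxygen would give a similar step in other cell lines.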